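A few compounds are considered here, and "the series" means these few. Any claim that something is new, unique, unknown or untested is made for them only; others in the source may bear on it.

Compound 1 `O=C(/C=C/c1ccc(OCc2nc(C3CCN(Cc4ccccc4F)CC3)no2)cc1)NO`: 68%
Compound 2 `COc1ccc(CN2CCC(c3noc(COc4ccc(/C=C/C(=O)NO)cc4)n3)CC2)cc1`: 75%
Compound 3 `CN(Cc1nc(C2CCN(Cc3ccccc3F)CC2)no1)c1ncc(C(=O)NO)cn1`: 44%

In an assay on isolated protein for inhibition of protein deacetylase HDAC6 (Homo sapiens), read by fluorescence, with a stated time of 1 h, tested at 100 nM (on this read-out lower numbers stand for less inhibition and higher numbers for more inhibition at the one concentration tested (going by the name of the read-out)), compound 3 stands lowest of the three measured compounds. Its nearest neighbour is compound 1, which lies higher by a margin beyond the scatter, and compound 2 lies higher still, also beyond the scatter. Compound 4 `CN(Cc1nc(C2CCN(Cc3ccc(F)cc3F)CC2)no1)c1ncc(C(=O)NO)cn1` differs from compound 3 in one place only: fluoro in place of hydrogen on an aromatic carbon. Cut one bond further out, the change reads as 2-fluorobenzyl to 2,4-difluorobenzyl on the saturated chain carbon bound to the ring amine nitrogen.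

Within the data shown here, only one measured step touches that part of the molecule. From compound 1 to compound 2 the whole 2-fluorophenyl was exchanged for 4-methoxyphenyl on that carbon, and the result was a number 7 percentage points higher from compound 1 to compound 2 (within the scatter). Among the measured compounds shown here, no measured pair shows a fluoro added to a ring that already carries one, so the bearing of that step on compound 4 is indirect. For the measured compounds named here, since the one related change stayed within the scatter, no step beyond the scatter is expected here either. Compound 4 is therefore estimated at 44%, in the range 30% to 58%. The step this estimate implies, no change at the digits printed from compound 3 to compound 4 (within the scatter), is expected to lie within the scatter.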

Compound 4, a percentage reported as inhibition, at one concentration (the size of the read-out at that concentration, not a potency): 66%
Estimate against measurement, compound 4: 22 percentage points below; measured number above the stated range.
By their numbers in this assay, from the lowest: compound 3; then compounds 4, 1 and 2 (each within the scatter of the next).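

In this assay the entry of one fluoro on the aromatic ring, para to a large group and meta to a fluoro group, gives a number 22 percentage points higher from compound 3 to compound 4 (beyond the scatter) and so marks this carbon as a place where a single added fluorine can move the read-out. Among these compounds, the earlier change at this end of the molecule gave only a number 7 percentage points higher from compound 1 to compound 2 (within the scatter) on the core of compound 1, so the step to compound 4 is the first one here that lies beyond the scatter, although the entering group has just one heavy atom and no hydrogen-bond donors or acceptors. Nothing measured here accounts for the size of this step.

Whether the same 2-fluorobenzyl to 2,4-difluorobenzyl change would have a similar effect on the core of compound 1 remains open, since that core is shown only with the 2-fluorophenyl and 4-methoxyphenyl groups. As far as these compounds go, it is also open whether the effect is particular to fluoro, or whether chloro, a nitrile or an amine on the same aromatic carbon would shift the number in the same direction or by a similar amount.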